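Swapping a halogenated aryl group on a branched enone

The compounds below may be only part of what the source reports. "The series", "measured", "known", "first", "only" and "open" are said of these compounds alone.

Compound 1 `CC(=O)OC/C(=C/c1ccc([N+](=O)[O-])cc1)C(=O)c1ccccc1` gives 36000 nM in a functional assay on T47D cells (Homo sapiens) for inhibition, read by sulforhodamine B assay, with a stated time of 48 h; a lower number here means a stronger inhibitor of growth, a higher number a weaker inhibitor of growth. Compound 2 `CC(=O)OC/C(=C/c1ccc(Cl)cc1)C(=O)c1ccc(Cl)cc1` gives 12000 nM in this assay, and compound 3 `C=C(C/C(=C\c1ccc(Cl)cc1)C(=O)c1ccccc1)C(=O)c1ccccc1` gives 19000 nM. Among these three numbers compound 3 stands second highest, yet its gap to compound 2 and its gap to compound 1 both fall inside the usual scatter, so the three compounds cannot be told apart on this evidence. Compound 4 `C=C(C/C(=C\c1ccccc1F)C(=O)c1ccccc1)C(=O)c1ccccc1` is not yet measured; it differs from compound 3 in one place: 2-fluorophenyl in place of 4-chlorophenyl on a double-bonded chain carbon bound to a double-bonded chain carbon. Going by the values given here, no measured pair shows this exchange, so nothing in the data points in either direction. Compound 4 is therefore expected to remain near compound 3, with an estimated step of a 1.1-fold higher number from compound 3 to compound 4 (0.02 log units; within the scatter) that stays within the scatter. The estimate for compound 4 in this assay is 20000 nM, with a range from 8000 nM to 50000 nM.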

Compound 4, concentration for 50% growth inhibition: 14000 nM
Compound 4: the middle estimate sits 1.4-fold (0.15 log units) above what was measured; low and high end bracket the measured number.
By their numbers in this assay, from the lowest: compounds 2, 4, 3 and 1 (each within the scatter of the next, the first and the last beyond it).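

The exchange of 2-fluorophenyl for 4-chlorophenyl on a double-bonded chain carbon bound to a double-bonded chain carbon gives a 1.4-fold lower number from compound 3 to compound 4 (0.13 log units; within the scatter) in this assay, and this is the only direct comparison at this position among the compounds shown. Compound 3 and compound 4 therefore cannot be told apart, so this position accepts this particular change of aryl group without a readable shift in growth inhibition. The identity of the halogen and its place on the ring change together here, and no data explain the result.

Going by these compounds, whether an unsubstituted phenyl, or a phenyl carrying an amine or a carboxylic acid, would move the number beyond the scatter at this position remains open. On these data alone, it is also open whether the same exchange would behave alike on the core of compound 1 or compound 2.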